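Removing the nitrile from the piperidine ring

This account rests on a few compounds, and the source may have more. Where it says the series, first, only, none or still open, it means among the compounds named here.

Compound 1 `COc1ccc2[nH]c(C(=O)N3CC(=O)N(Cc4ccccc4)[C@@H](CCc4ccccc4)C3)cc2c1` gives 4400 nM in this assay.
Compound 2 `COc1ccc2[nH]c(C(=O)N3CC(=O)N(Cc4ccccc4)[C@@H](CN4CCCCC4)C3)cc2c1` gives > 25000 nM.
Compound 3 `COc1ccc2[nH]c(C(=O)N3CC(=O)N(Cc4cccc(OC(F)F)c4)[C@@H](CN4CCC(C#N)CC4)C3)cc2c1` gives 27900 nM.

In a physicochemical assay for solubility, read by spectrophotometry, in phosphate buffer, with a stated time of 2 h, at pH 7.4 (a higher number here means a more soluble compound, a lower number a less soluble compound), compound 3 stands with the higher of the two numbers that were obtained. The value of compound 2 is a limit of the assay, not a number. For the measured compounds named here, the only measured step, an at least 5.6-fold higher number from compound 1 to compound 2 (0.75 log units; beyond the scatter), concerns a change at a different part of the molecule.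

Compound 4 `COc1ccc2[nH]c(C(=O)N3CC(=O)N(Cc4cccc(OC(F)F)c4)[C@@H](CN4CCCCC4)C3)cc2c1` differs from compound 3 in one place: hydrogen in place of cyano on a saturated ring carbon. Going by the values given here, no measured step changes this group, so the expectation rests on the neighbouring facts alone. Compound 2 carries the same plain piperidine ring as compound 4, and its result is the limit of > 25000 nM in this assay, at which 1 of the 3 values shown sits. Compound 3, with the cyano group present, already sits near that same boundary. The expected step is therefore a 1.1-fold lower number from compound 3 to compound 4 (0.05 log units; within the scatter), none beyond the scatter. The estimate for compound 4 is 25000 nM, with a range from 11000 nM to 55000 nM, and a fair chance that the assay reports only a limit.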

Compound 4, solubility: 26400 nM
Compound 4: middle estimate off by 1.1-fold (0.02 log units), on the low side, and the stated range covers the measured number.
By their numbers in this assay, from the lowest: compound 1; then compounds 4 and 3 (each within the scatter of the next).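

In this assay, the nitrile on the piperidine ring can now be judged on its own, at a saturated ring carbon three ring bonds from the ring nitrogen: a 1.1-fold lower number from compound 3 to compound 4 (0.02 log units; within the scatter). For the compounds shown here, at this position, then, cyano and hydrogen cannot be told apart in this read-out, which no earlier pair could show, as none of them changed this group. The step from compound 2 to compound 4, which adds difluoromethoxy to the aromatic ring, cannot be read, because compound 2 carries only a limit: the limit of > 25000 nM in this assay, at which 1 of the 4 values shown sits.

Going by these compounds, it remains open whether a carboxylic acid or a primary amine on the same ring carbon would read the same way. Also open, on these data alone, is whether a morpholine in place of the whole piperidine ring would leave the reading unchanged.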